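Adding a methyl group to compound 1

The compounds below may be only part of what the source reports. "The series", "measured", "known", "first", "only" and "open" are said of these compounds alone.

In a functional assay on Bel-7402 cells (Homo sapiens) for inhibition, read by MTT assay, with a stated time of 24 h, tested at 1 ug/mL (on this read-out higher numbers stand for more inhibition of growth at the one concentration tested and lower numbers for less inhibition of growth), compound 1 (`O=C(CCCCC(S)CCS)Nc1ccccc1`) gives 1.32% at the one concentration tested. Compound 3 (`O=C(CCCCC(S)CCS)Nc1ccc(OC(F)(F)F)cc1`) gives 7.32% which lies within the scatter of compound 1, so the two cannot be told apart, while compound 2 (`O=C(CCCCC(S)CCS)Nc1ccc(F)cc1`) is recorded as "not active" (no number reported) with no number attached. Compound 4 (`Cc1cccc(NC(=O)CCCCC(S)CCS)c1`) differs from compound 1 by methyl in place of hydrogen on an aromatic carbon as methyl in place of hydrogen on an aromatic carbon. Among the compounds with values here, only one measured step bears on this change, namely a number 6 percentage points higher from compound 1 to compound 3 (within the scatter) for trifluoromethoxy in place of hydrogen on an aromatic carbon. That step involves a different group, and no measurement covers methyl itself, so the guidance is limited. No step beyond the scatter is expected in this assay for this change, and the expected step is a number 2.7 percentage points higher from compound 1 to compound 4 (within the scatter) in size. Compound 4 may also be reported without a number, as compound 2 was. Compound 4 is estimated at 4% with an expected range from 0% to 13% across repeated measurements.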

Compound 4, percent growth inhibition at one concentration: 11.1%
The estimate for compound 4 lay 7.1 percentage points below the measured number; low and high end bracket the measured number.
By their numbers in this assay, from the lowest: compounds 1, 3 and 4 (each within the scatter of the next).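

In this assay the step for methyl in place of hydrogen on an aromatic carbon, meta to a large group, is a number 9.8 percentage points higher from compound 1 to compound 4 (within the scatter) and so does not separate compound 4 from compound 1. Within the data shown here, this is the first reading for methyl itself and for this place on the ring, whereas the only earlier step, a number 6 percentage points higher from compound 1 to compound 3 (within the scatter), concerned trifluoromethoxy, a different group. No independent measurement is available that could account for the size of this step.

Going by these compounds, whether any group at this place can produce a step beyond the scatter remains open, for instance an amine, a carboxylic acid or a longer chain such as propyl. On these data alone, it is also open whether methyl would behave the same way elsewhere on the ring, since this single step speaks only for the place tested.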